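The source may report more compounds than this note shows. Statements on the series, on what has been measured and on what is new or still open speak of the compounds shown alone.

Measured in a functional assay on CCRF-CEM cells (Homo sapiens) for antiproliferative activity; on this read-out lower numbers stand for stronger inhibition of growth and higher numbers for weaker inhibition of growth:
- compound 1 `CC/C=C\[C@H](C)[C@H](OC(N)=O)[C@@H](C)[C@H](O)[C@@H](C)C/C(C)=C\[C@H](C)[C@@H](O)[C@@H](C)/C=C\[C@@H](O)C[C@@H]1OC(=O)[C@H](C)C[C@H]1C`: 209 nM
- compound 2 `CC/C=C\[C@H](C)[C@H](OC(N)=O)[C@@H](C)[C@H](O)[C@@H](C)C/C(C)=C\[C@H](C)[C@@H](O)[C@@H](C)/C=C\[C@@H](O)C[C@H]1CCC(=O)O1`: 3810 nM

Compound 2, at 3810 nM, has the higher number of the two measured compounds. The move to compound 3 `CC/C=C\[C@H](C)[C@H](OC(N)=O)[C@@H](C)[C@H](O)[C@@H](C)C/C(C)=C\[C@H](C)[C@@H](O)[C@@H](C)/C=C\[C@@H](O)C[C@@H]1OC(=O)[C@H](C)[C@@H](OC)[C@H]1C` is a group of 11 heavy atoms (8 carbon, 3 oxygen; one six-membered non-aromatic ring with 1 hetero atom) in place of a group of 6 heavy atoms (4 carbon, 2 oxygen; one five-membered non-aromatic ring with 1 hetero atom), on a saturated chain carbon, two bonds along the chain from a double-bonded chain carbon and an oxygen on a saturated carbon. It takes place on a saturated chain carbon, two bonds along the chain from a double-bonded chain carbon and an oxygen on a saturated carbon.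

Going by the values given here, only one measured step bears on this: an 18-fold higher number from compound 1 to compound 2 (1.26 log units; beyond the scatter). That large step put a group with a five-membered non-aromatic ring in place of one with a six-membered non-aromatic ring at the same place. The new change runs the opposite way, so a large step towards a lower number is expected in this assay. The group entering here has not itself been measured, so the estimate stays wide. The expected change is a 19-fold lower number from compound 2 to compound 3 (1.28 log units; beyond the scatter). Compound 3 is estimated at 200 nM, with an expected range of 50 nM to 800 nM.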

Compound 3, concentration for 50% growth inhibition: 416 nM
The estimate for compound 3 lay 2.1-fold (0.32 log units) below the measured number, and the stated range covers the measured number.
By their numbers in this assay, from the lowest: compounds 1 and 3 (each within the scatter of the next); then compound 2.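

In this assay, the step of a 9.2-fold lower number from compound 2 to compound 3 (0.96 log units; beyond the scatter) shows that a six-membered ring group again gives a lower number than the five-membered one, this time with methoxy in place of hydrogen on a saturated ring carbon. The step of a 2.0-fold higher number from compound 1 to compound 3 (0.30 log units; within the scatter) shows that this methoxy leaves the number within the scatter, so the saturated ring carbon accepts the group without a measurable change in this read-out, and the gap to compound 2 does not depend on hydrogen standing there. No available measurement accounts for either step.

The compounds shown leave open whether a hydroxyl, an amine or a longer chain on that saturated ring carbon would also leave the number unchanged. They also leave open which features of the six-membered ring group separate it from the five-membered one.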